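This account rests on a few compounds, and the source may have more. Where it says the series, first, only, none or still open, it means among the compounds named here.

In a functional assay on cells (leukaemia cell line, Homo sapiens) for inhibition, read by sulforhodamine B assay, with a stated time of 48 h (on this read-out lower numbers stand for stronger inhibition of growth and higher numbers for weaker inhibition of growth), compound 1 (`Cc1cc(NS(=O)(=O)c2ccc(-c3cnc(C4CC4)o3)cc2)ccc1Cl`) gives 33400 nM, compound 2 (`O=S(=O)(Nc1ccc(Br)c(Cl)c1)c1ccc(-c2cnc(C3CC3)o2)cc1`) gives 70300 nM and compound 3 (`O=S(=O)(Nc1ccc(F)cc1F)c1ccc(-c2cnc(C3CC3)o2)cc1`) gives 66100 nM. Compound 2 thus sits level with compound 3 and only just clear of compound 1. Compound 4 (`O=S(=O)(Nc1cc(F)cc(Cl)c1)c1ccc(-c2cnc(C3CC3)o2)cc1`) carries 3-chloro-5-fluorophenyl in place of 4-bromo-3-chlorophenyl on a sulfonamide nitrogen, with 3-chloro-5-fluorophenyl in place of 4-bromo-3-chlorophenyl on a sulfonamide nitrogen. Two measured swaps on that nitrogen give a 2.1-fold higher number from compound 1 to compound 2 (0.32 log units; beyond the scatter) and a 2.0-fold higher number from compound 1 to compound 3 (0.30 log units; within the scatter). The closest guide is compound 3, which has also lost the 4-bromo-3-chlorophenyl, and that swap gave a 1.1-fold lower number from compound 2 to compound 3 (0.03 log units; within the scatter). No step beyond the scatter is therefore expected, and the expected change is a 1.2-fold lower number from compound 2 to compound 4 (0.07 log units; within the scatter). For compound 4, the estimated value is 60000 nM, with an expected range of 30000 nM to 100000 nM.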

Compound 4, concentration for total growth inhibition: 77500 nM
The estimate for compound 4 lay 1.3-fold (0.11 log units) below the measured number, and the stated range covers the measured number.
By their numbers in this assay, from the lowest: compounds 1, 3, 2 and 4 (each within the scatter of the next, the first and the last beyond it).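

With 3-chloro-5-fluorophenyl in place of 4-bromo-3-chlorophenyl on the sulfonamide nitrogen, the result is a 1.1-fold higher number from compound 2 to compound 4 (0.04 log units; within the scatter), and replacing 2,4-difluorophenyl gives a 1.2-fold higher number from compound 3 to compound 4 (0.07 log units; within the scatter), so compounds 2, 3 and 4 all lie within the scatter of one another. The step of a 2.3-fold higher number from compound 1 to compound 4 (0.37 log units; beyond the scatter) is modest and, like the step to compound 2, starts from the 4-chloro-3-methylphenyl group. Nothing available explains these steps. On these data alone, whether an amine, a carboxylic acid or a longer chain on that nitrogen would depart from these numbers remains open.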